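From a Saturated Chain to a Methylated Ethenyl Chain

This account rests on a few compounds, and the source may have more. Where it says the series, first, only, none or still open, it means among the compounds named here.

In a functional assay on MX1 cells (Homo sapiens) for inhibition, read by MTT assay, with a stated time of 120 h (a higher number here means a weaker inhibitor, a lower number a stronger inhibitor), compound 1 (`O=C(/C=C/c1ccc(NC(=O)Nc2ccc(Cl)c(C(F)(F)F)c2)cc1)NC1CCC1`) gives 4530 nM, while compound 2 (`CNC(=O)CCc1ccc(NC(=O)Nc2ccc(Cl)c(C(F)(F)F)c2)cc1`) gives 20400 nM, the higher of the two numbers, which makes compound 2 the weaker inhibitor of the pair. Compound 3 (`CNC(=O)/C=C(\C)c1ccc(NC(=O)Nc2ccc(Cl)c(C(F)(F)F)c2)cc1`) carries 1-methyl-2-(methylcarbamoyl)ethenyl in place of 2-(methylcarbamoyl)ethyl on an aromatic carbon, para to a large group (1-methyl-2-(methylcarbamoyl)ethenyl in place of 2-(methylcarbamoyl)ethyl on an aromatic carbon). Within the data shown here, only one measured step bears on this change: a 4.5-fold higher number from compound 1 to compound 2 (0.65 log units; beyond the scatter). Among the measured compounds shown here, that step alters the double bond and the cyclobutyl together, so the data cannot separate the two, and no measured compound shows the added methyl alone. Compound 3 shares an ethenyl chain with compound 1 and the methylcarbamoyl end with compound 2, so part of that step is expected to return in this assay. The expected change is a 2.0-fold lower number from compound 2 to compound 3 (0.31 log units; beyond the scatter). Compound 3 is estimated at 10000 nM, with an expected range of 4000 nM to 25000 nM.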

Compound 3, half-maximal inhibitory concentration: > 50000 nM
Compound 3: no number, only a limit (the forecaster's own chance of this, stated with the estimate: 8%); middle value at least 5.0-fold (0.69 log units) away from the limit.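

Compound 3 gives no number, only a limit of the assay: the limit of > 50000 nM in this assay, at which 1 of the 3 values shown sits. Even so, the direction is readable in this assay: putting 1-methyl-2-(methylcarbamoyl)ethenyl in place of 2-(methylcarbamoyl)ethyl on an aromatic carbon, para to a large group, gives an at least 2.4-fold higher number from compound 2 to compound 3 (0.38 log units; beyond the scatter), so the earlier step did not return in part with this chain. Exchanging 2-(cyclobutylcarbamoyl)ethenyl for the same chain gives an at least 11-fold higher number from compound 1 to compound 3 (1.04 log units; beyond the scatter), which shows that an ethenyl chain at this position does not by itself keep the lower number.

The compounds shown do not separate the added methyl from the change at the amide end. Going by these compounds, how a 2-(methylcarbamoyl)ethenyl chain without that methyl, or a chain ending in a carboxylic acid or an amine, would read here remains open.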